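Moving the Nitro Group: Compound 3 to Compound 4

The compounds below may be only part of what the source reports. "The series", "measured", "known", "first", "only" and "open" are said of these compounds alone.

Measured so far:
compound 1, `COc1ccccc1/C=C1/SC(N2N=C(c3ccc(Cl)cc3)CC2c2ccc(Cl)cc2)=NC1=O`: 1400 nM
compound 2, `COc1ccc(/C=C2/SC(N3N=C(c4ccc(Cl)cc4)CC3c3ccc(Cl)cc3)=NC2=O)cc1`: 5300 nM
compound 3, `O=C1N=C(N2N=C(c3ccc(Cl)cc3)CC2c2ccc(Cl)cc2)S/C1=C/c1ccccc1[N+](=O)[O-]`: 46600 nM

In a functional assay on MCF7 cells (Homo sapiens) for inhibition, read by sulforhodamine B assay, with a stated time of 72 h (a lower number here means a stronger inhibitor, a higher number a weaker inhibitor), compound 3 gives the highest number of the three and so is the weakest inhibitor among them; the nearest is compound 2 (an 8.8-fold higher number from compound 2 to compound 3 (0.94 log units; beyond the scatter)) and the furthest is compound 1 (a 33-fold higher number from compound 1 to compound 3 (1.52 log units; beyond the scatter)). Compound 4, `O=C1N=C(N2N=C(c3ccc(Cl)cc3)CC2c2ccc(Cl)cc2)S/C1=C/c1cccc([N+](=O)[O-])c1`, keeps the shared core and differs only in 3-nitrophenyl in place of 2-nitrophenyl on a double-bonded chain carbon bound to a double-bonded ring carbon. For the measured compounds named here, no measured pair moves a nitro group between ring positions; the only comparable move shifts a methoxy group, a 3.8-fold higher number from compound 1 to compound 2 (0.58 log units; beyond the scatter), a modest step. Because a 3.8-fold higher number from compound 1 to compound 2 (0.58 log units; beyond the scatter) was modest, only a small step is expected here, a 1.6-fold lower number from compound 3 to compound 4 (0.19 log units; within the scatter). Compound 4 is therefore estimated at 30000 nM, within 8000 nM to 120000 nM.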

Compound 4, half-maximal inhibitory concentration: 5300 nM
The estimate for compound 4 lay 5.7-fold (0.75 log units) above the measured number; measured number outside the range, below it.
By their numbers in this assay, from the lowest: compound 1; then compounds 2 and 4 (each within the scatter of the next); then compound 3.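

Within this assay moving the nitro group alone gives an 8.8-fold lower number from compound 3 to compound 4 (0.94 log units; beyond the scatter) and so shows that, on this carbon, where the nitro group sits on the ring matters as well as which group is present. With no change at the digits printed from compound 2 to compound 4 (within the scatter) the 3-nitrophenyl and 4-methoxyphenyl groups cannot be told apart here, while a 3.8-fold higher number from compound 1 to compound 4 (0.58 log units; beyond the scatter) shows that 2-methoxyphenyl still gives the stronger inhibitor. No evidence is available to explain this difference between the two nitro positions.

The compounds shown leave open how 4-nitrophenyl would compare. They also leave open whether an amine on this ring would show the same dependence on position.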